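This account rests on a few compounds, and the source may have more. Where it says the series, first, only, none or still open, it means among the compounds named here.

Of the compounds shown here, three of a shared core have been tested in an ADME assay on A549 cells (Homo sapiens) for cytotoxicity, read by resazurin assay, with a stated time of 48 h; a higher number here means that more compound is tolerated, a lower number that less compound is tolerated. Compound 1 `CCCNc1ccc(NC(=O)c2cc(Cl)ccc2O)c(Cl)c1` gives 22500 nM, compound 2 `O=C(Nc1ccc(NCC2CC2)cc1Cl)c1cc(Cl)ccc1O` gives 14400 nM, and compound 3 `CN(C)c1ccc(NC(=O)c2cc(Cl)ccc2O)c(Cl)c1` gives 85100 nM. Compound 2 stands at the low end of these three numbers, but its gap to compound 1, a 1.6-fold lower number from compound 1 to compound 2 (0.19 log units; within the scatter), is within the scatter, whereas the step of a 5.9-fold higher number from compound 2 to compound 3 (0.77 log units; beyond the scatter) is beyond it, as is a 3.8-fold higher number from compound 1 to compound 3 (0.58 log units; beyond the scatter).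

Compound 4 `CC(C)(CCO)Nc1ccc(NC(=O)c2cc(Cl)ccc2O)c(Cl)c1` has not yet been measured. Compared with compound 2 it carries 3-hydroxy-1,1-dimethylpropyl in place of cyclopropylmethyl on a nitrogen on an aromatic ring.

Two of the measured steps bear on this change. The step from compound 1 to compound 2 swapped one small chain end for another at the same nitrogen and stayed within the scatter. The steps to compound 3 shortened the group on that nitrogen and gave a modest rise. Among the compounds with values here, the change to compound 4 lengthens the group instead and brings in a hydroxyl, for which no measured step exists. Compound 4 is therefore expected to stay close to compound 2, with the step of a 1.5-fold higher number from compound 2 to compound 4 (0.18 log units; within the scatter) estimated as small or none beyond the scatter. The estimated value for compound 4 in this assay is 22000 nM, within a range of 8000 nM to 60000 nM.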

Compound 4, half-maximal cytotoxic concentration: 170000 nM
Beside the measured number, compound 4's estimate is 7.7-fold (0.89 log units) below it; measured number outside the range, above it.
By their numbers in this assay, from the lowest: compounds 2 and 1 (each within the scatter of the next); then compounds 3 and 4 (each within the scatter of the next).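

Within the data shown here, at this nitrogen on an aromatic ring, the choice of group can shift the number in this assay much further than the earlier compounds showed, with the step of a 12-fold higher number from compound 2 to compound 4 (1.07 log units; beyond the scatter) the largest so far and the step of a 7.6-fold higher number from compound 1 to compound 4 (0.88 log units; beyond the scatter) also beyond the scatter. More heavy atoms on this nitrogen need not mean a lower number, since the 3-hydroxy-1,1-dimethylpropyl group cannot be told apart from the much smaller dimethylamino arrangement, as the step of a 2.0-fold higher number from compound 3 to compound 4 (0.30 log units; within the scatter) shows. Nothing measured here gives a reason for this rise.

Still open, on these data alone, is whether a plain 1,1-dimethylpropyl group without the hydroxyl, or an unbranched 3-hydroxypropyl chain, would give the same number, and so which part of the new group carries the step. As far as these compounds go, how a carboxylic acid at the chain end in place of the hydroxyl would read also stays open.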